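The source may hold more compounds than are shown below. What is called first, only, known or untested is meant among the compounds shown, and "the series" means these compounds.

Compound 1 `CC(C)(C)c1ccc(CNCCCNS(=O)(=O)c2cc(C(F)(F)F)cc(C(F)(F)F)c2)cc1` gives 2500 nM in a functional assay on PANC-1 cells (Homo sapiens) for inhibition, read by MTT assay, with a stated time of 72 h; on this read-out lower numbers stand for stronger inhibition of growth and higher numbers for weaker inhibition of growth; compound 2 `O=S(=O)(NCCCNCc1ccc(Cl)c(C(F)(F)F)c1)c1cc(C(F)(F)F)cc(C(F)(F)F)c1` gives 10000 nM in this assay.

Going by the values given here, compound 2 stands at the higher of the two numbers, its only neighbour being compound 1 at a 4.0-fold higher number from compound 1 to compound 2 (0.60 log units; beyond the scatter). Compound 3 `COc1ccccc1CNCCCNS(=O)(=O)c1cc(C(F)(F)F)cc(C(F)(F)F)c1` differs from compound 2 by 2-methoxyphenyl in place of 4-chloro-3-(trifluoromethyl)phenyl on a saturated chain carbon bound to an amine nitrogen. Among the compounds with values here, the one step that bears on this change in the same place, a 4.0-fold higher number from compound 1 to compound 2 (0.60 log units; beyond the scatter), shows that swapping the aryl group on that chain carbon can move the number by a modest amount. Within the data shown here, with no measured step involving the entering group, compound 3 is estimated at 12000 nM (range 4000 nM to 40000 nM), an expected step of a 1.2-fold higher number from compound 2 to compound 3 (0.08 log units; within the scatter), likely within the scatter.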

Compound 3, concentration for 50% growth inhibition: 12000 nM
Compound 3: the middle estimate sits on the measured number at the digits printed; measured number inside the range.
By their numbers in this assay, from the lowest: compound 1; then compounds 2 and 3 (each within the scatter of the next).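

Putting 2-methoxyphenyl in place of 4-chloro-3-(trifluoromethyl)phenyl on a saturated chain carbon bound to an amine nitrogen gives a 1.2-fold higher number from compound 2 to compound 3 (0.08 log units; within the scatter) and so does not separate these two aryl groups in this assay despite their different substituents. Set against 4-(tert-butyl)phenyl, the same group gives a 4.8-fold higher number from compound 1 to compound 3 (0.68 log units; beyond the scatter) and so leaves compound 1 alone at the lower number of the three. Nothing available explains these numbers.

The compounds shown leave open how a plain phenyl or a phenyl carrying a carboxylic acid would read at this position. They also leave open whether a longer chain would change the number.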